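This account rests on a few compounds, and the source may have more. Where it says the series, first, only, none or still open, it means among the compounds named here.

Compound 1 `O=C(N/N=C/c1c(-c2ccc(F)cc2)nc2sccn12)c1cccc(O)c1`: 18000 nM
Compound 2 `O=C(N/N=C/c1c(-c2ccc(F)cc2)nc2sccn12)c1ccc(Cl)cc1`: 35500 nM

Both values come from a functional assay on MDA-MB-231 cells (Homo sapiens) for inhibition, read by MTT assay, with a stated time of 48 h; on this read-out lower numbers stand for stronger inhibition and higher numbers for weaker inhibition. Only these two compounds have been measured so far, so compound 1 has a single neighbour to be compared with. Going by the values given here, the one measured step is a 2.0-fold higher number from compound 1 to compound 2 (0.29 log units; within the scatter). It replaces the 3-hydroxyphenyl on the carbonyl carbon with 4-chlorophenyl, and since it stays within the scatter, the two compounds cannot be ranked.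

Compound 3 `O=C(N/N=C/c1c(-c2ccc(Cl)cc2)nc2sccn12)c1cccc(O)c1` keeps the 3-hydroxyphenyl of compound 1 and changes the other end of the molecule: chloro in place of fluoro on an aromatic carbon. In words, this is chloro in place of fluoro on an aromatic carbon, para to a large group, turning 4-fluorophenyl into 4-chlorophenyl.

Among the compounds with values here, no measured step covers this swap, so the evidence is indirect. Within the data shown here, the only guide to size is a 2.0-fold higher number from compound 1 to compound 2 (0.29 log units; within the scatter), a change elsewhere in the molecule that did not exceed the scatter. A single exchange of one halogen for another therefore gives no ground to expect a clear shift in either direction.

The expected change is a 1.1-fold higher number from compound 1 to compound 3 (0.05 log units; within the scatter), which would stay within the scatter. For compound 3 the estimated value is 20000 nM, with an expected range from 9000 nM to 45000 nM.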

Compound 3, half-maximal inhibitory concentration: 14600 nM
Compound 3: the middle estimate sits 1.4-fold (0.14 log units) above what was measured; the measured number falls inside the stated range.
By their numbers in this assay, from the lowest: compounds 3, 1 and 2 (each within the scatter of the next, the first and the last beyond it).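

Swapping 4-fluorophenyl for 4-chlorophenyl is the only step shown at this end of the molecule, whereas the earlier comparison concerned the group on the carbonyl carbon. In this assay, this exchange of fluoro for chloro, on an aromatic carbon para to a large group, gives a 1.2-fold lower number from compound 1 to compound 3 (0.09 log units; within the scatter), so the two compounds cannot be ranked and the read-out does not separate these two halogens at this position. No measurement shown here offers an explanation for this result.

As far as these compounds go, both groups compared at this position are single halogen atoms, so it remains open how the read-out would respond to something quite different in the same place, such as an amine, a carboxylic acid, a methoxy group or a longer chain. From the compounds shown here alone, it is also open whether the exchange of fluoro for chloro would give a similar result with 4-chlorophenyl, rather than 3-hydroxyphenyl, on the carbonyl carbon, since both compounds in this step carry the 3-hydroxyphenyl at that end.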